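This account rests on a few compounds, and the source may have more. Where it says the series, first, only, none or still open, it means among the compounds named here.

Working notes on a small set of compounds tested in a functional assay for antagonist activity at transient receptor potential cation channel subfamily V member 1 (Homo sapiens), read by FLIPR; a higher number here means a weaker inhibitor, a lower number a stronger inhibitor.

Compound 1 `C[C@@H]1CN(c2ncccc2C(F)(F)F)CCN1C(=O)Nc1ccc(C(F)(F)F)cc1` gives 17 nM. Compound 2 `Cc1cccnc1-c1ccc(C(=O)Nc2ccc(C(C)C)cc2)cc1` gives 73 nM. Compound 3 `CCCNc1cccnc1-c1ccc(C(=O)Nc2ccc(C(C)(C)C)cc2)cc1` gives 158 nM, the highest number of the three; its nearest neighbour is compound 2, whose number is lower by a margin beyond the usual scatter, and compound 1 lies further below it, also beyond the scatter. No pair among these three differs in one place only, so no single step can be read off from them; what each pair shows is only its two values.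

Compound 4 `CC(C)(C)c1ccc(NC(=O)c2ccc(-c3ncccc3C(=N)N)cc2)cc1` has not yet been measured. It differs from compound 3 by a group of 3 heavy atoms (1 carbon, 2 nitrogen; no ring) in place of a group of 4 heavy atoms (3 carbon, 1 nitrogen; no ring), on an aromatic carbon. The incoming group has two hydrogen-bond donors where the propylamino group had one, and one fewer heavy atom. Within the data shown here, with no comparable step among the measured compounds, the expectation rests on compound 3 alone; the number for compound 4 is expected to move upward, by a step of a 2.5-fold higher number from compound 3 to compound 4 (0.40 log units; beyond the scatter), beyond the scatter but not by a large margin. Compound 4 is estimated at 400 nM, within a range of 120 nM to 1500 nM.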

Compound 4, half-maximal inhibitory concentration: > 4000 nM
Compound 4: a limit, no number (the forecaster's own chance of this, stated with the estimate: 12%); at least 10-fold (1.00 log units) between middle value and limit.
By their numbers in this assay, from the lowest: compound 1; then compound 2; then compound 3. At a limit, above all of these: compound 4.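

Among these compounds, this is the first step that can be read at a single place. On the aromatic carbon two atoms from the ring nitrogen, the incoming group in place of propylamino gives an at least 25-fold higher number from compound 3 to compound 4 (1.40 log units; beyond the scatter) in this assay, so this position does not accept every small group with hydrogen-bond donors, and the exchange costs a large part of the activity. Compound 4 has a limit and not a number, so the full size of the step stays unread: the limit of > 4000 nM in this assay, at which 1 of the 4 values shown sits.

The compounds shown do not separate the loss of the propyl chain from the arrival of the double bond and the extra donor. A simple amine, a methoxy group or a butylamino chain on this carbon would bear on that question.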